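Dihydropyridine esters: aryl swap from compound 2 to compound 3

The source may report more compounds than this note shows. Statements on the series, on what has been measured and on what is new or still open speak of the compounds shown alone.

Measured so far:
compound 1, `COC(=O)C1=C(C)N=C(C)/C(=C(\O)OC)C1c1ccccc1C(F)(F)F`, 1.51 nM
compound 2, `COC(=O)C1=C(C)N=C(C)/C(=C(\O)OC)C1c1ccc(I)cc1`, 22900 nM

In a functional assay (muscle tissue) with Cavia porcellus as the target (on this read-out higher numbers stand for an effect only at larger amounts of compound and lower numbers for an effect already at smaller amounts), compound 2 gives 22900 nM, the highest of the two numbers recorded. For the measured compounds named here, its only neighbour is compound 1, which in this assay gives 1.51 nM; the gap between the two lies far beyond the usual scatter, so compound 2 is clearly the weaker of the pair. Going by the values given here, no single-change step between measured compounds is available, so the two values can only be set side by side.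

Compound 3, `COC(=O)C1=C(C)N=C(C)/C(=C(\O)OC)C1c1ccccc1Br`, is not yet measured in this assay. It differs from compound 2 as follows: 2-bromophenyl in place of 4-iodophenyl on a saturated ring carbon.

Because compound 1 sits at 1.51 nM while compound 2 sits at 22900 nM, a large downward step is expected from compound 2 to compound 3, with the estimate a 2300-fold lower number from compound 2 to compound 3 (3.36 log units; beyond the scatter). For compound 3 the expected value in this assay is 10 nM, with a range from 1 nM to 300 nM. This rests on two compounds only and is to be tested.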

Compound 3, half-maximal effective concentration: 7.59 nM
The estimate for compound 3 lay 1.3-fold (0.12 log units) above the measured number; measured number inside the range.
By their numbers in this assay, from the lowest: compound 1; then compound 3; then compound 2.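

The 2-bromophenyl in place of 4-iodophenyl on a saturated ring carbon gives a 3000-fold lower number from compound 2 to compound 3 (3.48 log units; beyond the scatter) in this assay, so this position of the series tolerates very different outcomes between two aryl groups of equal heavy-atom count, neither of which carries a hydrogen-bond donor, an acceptor or a net charge. Compound 3 also shows that a low number at this place does not depend on trifluoromethyl alone: bromo in place of trifluoromethyl on an aromatic carbon gives a 5.0-fold higher number from compound 1 to compound 3 (0.70 log units; beyond the scatter) in this assay, a modest step beyond the scatter and small beside the change from the 4-iodophenyl compound. Among the compounds shown, the two aryl groups that give low numbers are the two that differ from 4-iodophenyl in both substituent and substitution place, which keeps the reading to compounds 1, 2 and 3.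

As far as these compounds go, the large step changes the halogen and its place on the aryl ring together, so the share of each remains open. Also open, from the compounds shown here alone, is how an amine or a nitro group would read on that aromatic carbon, and how a longer ester chain on the shared core would read. No independent measurement accompanies these numbers that could account for the size of either step.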